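Replacing a pyridine with a pyrimidinol in chemokine receptor antagonists

The source may hold more compounds than are shown below. What is called first, only, known or untested is meant among the compounds shown, and "the series" means these compounds.

Three compounds have been measured in a functional assay on isolated protein for antagonist activity at C-C chemokine receptor type 9 (Homo sapiens), read by calcium flux, with a stated time of 10 min; on this read-out higher numbers stand for weaker inhibition and lower numbers for stronger inhibition:

Compound 1 `COc1cccnc1-c1cc(Cl)ccc1NS(=O)(=O)c1ccc(C(C)(C)C)cc1` gives 958 nM
Compound 2 `CC(C)(C)c1ccc(S(=O)(=O)Nc2ccc(Cl)cc2-c2nc(N)ncc2O)cc1` gives 4 nM
Compound 3 `CN(C)c1ncnc(-c2cc(Cl)ccc2NS(=O)(=O)c2ccc(C(C)(C)C)cc2)c1O` gives 9 nM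

Compound 1 stands highest of the three numbers, with compound 3 nearest to it at a 110-fold lower number from compound 1 to compound 3 (2.03 log units; beyond the scatter) and compound 2 furthest at a 240-fold lower number from compound 1 to compound 2 (2.38 log units; beyond the scatter). Both of these steps replace the same 3-methoxypyridin-2-yl group of compound 1 with a six-membered aromatic ring bearing 2 hetero atoms, and both are large and beyond the scatter. Between compound 2 and compound 3 the step is a 2.3-fold higher number from compound 2 to compound 3 (0.35 log units; beyond the scatter), which is modest.

The unmeasured compound 4 `CC(C)(C)c1ccc(S(=O)(=O)Nc2ccc(Cl)cc2-c2ncnc(CO)c2O)cc1` takes the same route. Its change from compound 1 is a group of 9 heavy atoms (5 carbon, 2 nitrogen, 2 oxygen; one six-membered aromatic ring with 2 hetero atoms) in place of a group of 8 heavy atoms (6 carbon, 1 nitrogen, 1 oxygen; one six-membered aromatic ring with 1 hetero atom), on an aromatic carbon. The steps from compound 1 to compound 2 and from compound 1 to compound 3 are the ones that bear on it: each swaps the pyridine for a pyrimidinol and each lowers the number by a large step. Compound 4 is therefore expected to show a large step down, estimated as an 80-fold lower number from compound 1 to compound 4 (1.90 log units; beyond the scatter). Compound 4 is expected to give about 12 nM, within a range of 3 nM to 50 nM, placing it near compound 2 and compound 3 rather than near compound 1.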

Compound 4, half-maximal inhibitory concentration: 11 nM
Compound 4: middle estimate off by 1.1-fold (0.04 log units), on the high side; low and high end bracket the measured number.
By their numbers in this assay, from the lowest: compound 2; then compounds 3 and 4 (each within the scatter of the next); then compound 1.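

In this assay the large step of an 87-fold lower number from compound 1 to compound 4 (1.94 log units; beyond the scatter) shows that the drop on leaving 3-methoxypyridin-2-yl does not depend on an amine on the entering ring: compound 2 and compound 3 both carry one, whereas compound 4 carries hydroxymethyl instead. The step of a 1.2-fold higher number from compound 3 to compound 4 (0.09 log units; within the scatter) lies within the scatter, so putting hydroxymethyl in place of dimethylamino makes no readable difference here. The step of a 2.8-fold higher number from compound 2 to compound 4 (0.44 log units; beyond the scatter) is beyond the scatter but modest, so the entering groups of compound 2 and compound 4 are separated by far less than either is from the group of compound 1.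

Compound 2, compound 3 and compound 4 all keep the ring hydroxyl together with the second ring nitrogen, so the shown compounds leave open which of the two carries the drop, and whether a carboxylic acid or a longer chain in place of hydroxymethyl would keep the number this low. No measurement is at hand that explains the size of these steps.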